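Cyano in Place of Formyl: Expected Cytotoxicity of Compound 4

This account rests on a few compounds, and the source may have more. Where it says the series, first, only, none or still open, it means among the compounds named here.

Measured compounds in a functional assay on MCF7 cells (Homo sapiens) for cytotoxicity, tested at 10 uM; a lower number here means less inhibition, a higher number more inhibition at the concentration tested (going by the name of the read-out):
compound 1 `O=Cc1c(-c2ccccc2)sc2ccccc12` gives 51%
compound 2 `O=Cc1c(-c2ccc(C(F)(F)F)cc2)sc2ccccc12` gives 73%
compound 3 `O=Cc1c(-c2ccc(Cl)cc2)sc2ccccc12` gives 69%

Compound 3 sits above compound 1, with a number 18 percentage points higher from compound 1 to compound 3 (beyond the scatter). Its value and that of compound 2 differ by a number 4 percentage points lower from compound 2 to compound 3 (within the scatter), so these two cannot be told apart. Compound 2 in turn lies above compound 1 by a number 22 percentage points higher from compound 1 to compound 2 (beyond the scatter). Both steps that cross the scatter come from adding a group to the phenyl ring, and neither touches the formyl group.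

Compound 4 `N#Cc1c(-c2ccc(Cl)cc2)sc2ccccc12` has not yet been measured. It differs from compound 3 in one place: cyano in place of formyl on an aromatic carbon. Going by the values given here, no measured step bears on this change, since every step among compounds 1, 2 and 3 concerns the phenyl ring, while the chloro group that raised the value of compound 3 is kept in compound 4. With no guidance from the data on what cyano in place of formyl does, the expectation is a step of a number 4 percentage points lower from compound 3 to compound 4 (within the scatter), which is taken as none beyond the scatter. Compound 4 is therefore estimated at 65%, with a range from 40% to 85%.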

Compound 4, a percentage reported as inhibition, at one concentration (the size of the read-out at that concentration, not a potency): 27%
Beside the measured number, compound 4's estimate is 38 percentage points above it, outside the stated range (below it).
By their numbers in this assay, from the lowest: compound 4; then compound 1; then compounds 3 and 2 (each within the scatter of the next).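

At this position, on an aromatic carbon two ring bonds from the ring sulfur, the group matters a great deal in this assay: cyano in place of formyl gives a number 42 percentage points lower from compound 3 to compound 4 (beyond the scatter) even though the chloro group on the phenyl ring stays in place. The earlier steps shown here only showed what happens on the phenyl ring, whereas this one shows that a change at the formyl position can outweigh the gain seen with chloro. The size of the step cannot be traced to the simple counts, as formyl and cyano match in heavy atoms, hydrogen-bond donors and hydrogen-bond acceptors, and they differ in oxygen against nitrogen and in a double against a triple bond, but nothing available here explains why the change has this effect.

The compounds shown leave open how a carboxylic acid, an amine or a longer chain at this position would behave in this assay, and so whether the number is unusually high with formyl or unusually low with cyano. Also open, from the compounds shown here alone, is whether the same change would give a similar step with trifluoromethyl or hydrogen on the phenyl ring, as it is seen here only with chloro.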